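A few compounds are considered here, and "the series" means these few. Any claim that something is new, unique, unknown or untested is made for them only; others in the source may bear on it.

Compound 1 `C=CC(=O)N1C(=O)CC(c2ccc(OC)cc2)Sc2ccccc21` was tested in a functional assay on HL-60 cells (Homo sapiens) for cytotoxicity, read by CCK-8 assay, with a stated time of 24 h (a lower number here means a stronger inhibitor, a higher number a weaker inhibitor), where compound 1 gives 92100 nM, the lowest of the two numbers measured here. Its nearest neighbour, compound 2 `C=CC(=O)N1C(=O)CC(C)Sc2ccccc21`, gives 199000 nM in this assay, and the step of a 2.2-fold higher number from compound 1 to compound 2 (0.33 log units; beyond the scatter) arises from a methyl in place of 4-methoxyphenyl on a saturated ring carbon. Compound 3 `C=CC(=O)N1C(=O)CC(c2cccs2)Sc2ccccc21` has not yet been measured. It differs from compound 1 by thiophen-2-yl in place of 4-methoxyphenyl on a saturated ring carbon. Among the measured compounds shown here, the only measured step at this same saturated ring carbon is a 2.2-fold higher number from compound 1 to compound 2 (0.33 log units; beyond the scatter), a modest one, and it swaps the aromatic group for a methyl rather than for another aromatic ring. Thiophen-2-yl keeps an aromatic ring at this carbon, unlike the methyl of compound 2. The step of a 1.3-fold higher number from compound 1 to compound 3 (0.11 log units; within the scatter) is therefore expected to be small, within the scatter or leaning slightly toward a higher number. Compound 3 is estimated at 120000 nM, with a range from 55000 nM to 260000 nM.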

Compound 3, half-maximal inhibitory concentration: 695000 nM
Estimate against measurement, compound 3: 5.8-fold (0.76 log units) below; measured number outside the range, above it.
By their numbers in this assay, from the lowest: compound 1; then compound 2; then compound 3.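

In this assay, replacing 4-methoxyphenyl with thiophen-2-yl gives a large change (a 7.5-fold higher number from compound 1 to compound 3 (0.88 log units; beyond the scatter)), so an aromatic ring at this saturated ring carbon does not by itself keep the number low. The thiophen-2-yl compound also gives a higher number than the methyl compound (a 3.5-fold higher number from compound 2 to compound 3 (0.54 log units; beyond the scatter)), which places methyl between the two aromatic groups, so these three compounds do not sort simply into aromatic and non-aromatic. Nothing available explains why the two aromatic groups differ.

The compounds shown cannot tell whether the lower number of compound 1 comes from its six-membered ring or from its methoxy group, since a plain phenyl group is not among them. On these data alone, how an amine or a longer alkyl chain at this carbon would behave also remains open.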